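The compounds below may be only part of what the source reports. "The series", "measured", "known", "first", "only" and "open" are said of these compounds alone.

Of the compounds shown here, two sharing one core have been tested in an assay on isolated protein for inhibition of mitogen-activated protein kinase kinase kinase 9 (Homo sapiens); on this read-out higher numbers stand for weaker inhibition and lower numbers for stronger inhibition. Compound 1 `COc1ccc2c(c1)CCc1c-2c2c(c3c4ccccc4n(CCCO)c13)CNC2=O` gives 101 nM in this assay. Compound 2 `COc1ccc2c(c1)CCc1c-2c2c(c3c1[nH]c1ccccc13)CNC2=O` gives 188 nM in this assay. Within the data shown here, the only step measured so far, a 1.9-fold higher number from compound 1 to compound 2 (0.27 log units; within the scatter), goes with hydrogen in place of 3-hydroxypropyl on an aromatic nitrogen. Compound 2 thus holds the highest of the two numbers, and its nearest neighbour, compound 1, lies within the scatter of it.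

Compound 3 `CC(C)Oc1ccc2c(c1)CCc1c-2c2c(c3c1[nH]c1ccccc13)CNC2=O` is not yet measured. It differs from compound 2 by isopropyl in place of methyl on an oxygen on an aromatic ring. Among the measured compounds shown here, no measured step touches this oxygen, and the one step available altered another position without leaving the scatter. The data therefore give no ground to expect a shift beyond the scatter in this assay. Compound 3 is expected to give about 200 nM, with a range from 70 nM to 600 nM. The expected step is a 1.1-fold higher number from compound 2 to compound 3 (0.03 log units; within the scatter).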

Compound 3, half-maximal inhibitory concentration: 66 nM
The estimate for compound 3 lay 3.0-fold (0.48 log units) above the measured number, and the stated range ends above it.
By their numbers in this assay, from the lowest: compounds 3, 1 and 2 (each within the scatter of the next, the first and the last beyond it).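

In this assay, among these compounds, the change from methoxy to isopropoxy gives a 2.8-fold lower number from compound 2 to compound 3 (0.45 log units; beyond the scatter) and is the first step in this set to lie beyond the scatter. Among the compounds shown here, this shows that the group on this oxygen can influence the read-out, whereas the only earlier step, made on the aromatic nitrogen, stayed within the scatter. Here isopropyl, with 3 heavy atoms against 1 for methyl, goes with modestly stronger inhibition, and nothing measured here explains why.

The compounds shown carry only methyl and isopropyl on this oxygen, so it remains open whether a longer chain, a cyclopentyl ring or a chain ending in an amine would lower the number further or raise it. Going by these compounds, it is also open whether isopropyl would give a similar step alongside the 3-hydroxypropyl group of compound 1.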